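Swapping a Cyclic Amine Side Chain for an Amide-Linked Amine

This account rests on a few compounds, and the source may have more. Where it says the series, first, only, none or still open, it means among the compounds named here.

Measured compounds in an ADME assay on HL-60 cells (Homo sapiens) for cytotoxicity, read by resazurin assay, with a stated time of 72 h; a higher number here means that more compound is needed for the effect, a lower number that less compound is needed:
Compound 1 `O=C(c1ccccc1)c1ccc2nc(NCCO)[nH]c2c1`: > 30000 nM, a limit of the assay.
Compound 2 `O=C(c1ccccc1)c1ccc2nc(NCCC3CCCNC3)[nH]c2c1`: > 30000 nM, a limit of the assay.
Compound 3 `O=C(NCCO)Nc1nc2cc(C(=O)c3ccccc3)ccc2[nH]1`: > 30000 nM, a limit of the assay.

Compound 2 therefore stands at the limit of > 30000 nM in this assay, at which 3 of the 3 values shown sit, so no number is known for it. Compound 4 `NCCCC(=O)Nc1nc2ccc(C(=O)c3ccccc3)cc2[nH]1` differs from it by (3-aminopropyl)carbonyl in place of 2-(piperidin-3-yl)ethyl on a nitrogen on an aromatic ring. Among the measured compounds shown here, the only measured step that touches compound 2 is a step that the two limits leave unreadable from compound 1 to compound 2, and it cannot show how large a change in this side chain makes in this assay; no measured step bears on the new change either. The expectation for compound 4 in this assay is therefore a step that the limit leaves unreadable from compound 2 to compound 4, none beyond the scatter. Compound 4 is estimated at 40000 nM, within 12000 nM to 150000 nM.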

Compound 4, half-maximal effective concentration: > 30000 nM
Compound 4: a limit, no number (the forecaster's own chance of this, stated with the estimate: 75%); the middle value does not contradict the limit.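

Compound 4, like compound 1 and compound 2, gives only a limit rather than a number, so neither of its steps from those two compounds can be read. From the compounds shown here alone, how far any of these side chains shifts the effect in this assay remains open.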